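A few compounds are considered here, and "the series" means these few. Any claim that something is new, unique, unknown or untested is made for them only; others in the source may bear on it.

Compound 1 `CC(Cn1ncccc1=O)C(=N)S` gives 40.3% in a functional assay on the whole organism (stomach) for inhibition, with Rattus norvegicus as the target, at a dose of 100 mg/kg by the intraduodenal route; a higher number here means more inhibition at the dose given (going by the name of the read-out), a lower number less inhibition.
Compound 2 `N=C(S)CCn1ncccc1=O` gives 28.8% in this assay.
Compound 3 `CC(CC(=N)S)n1ncccc1=O` gives 38.8% in this assay.

Compound 2 stands lowest of the three numbers in this assay: compound 3 lies within the scatter of it, while compound 1 lies beyond it, the step being a number 11.5 percentage points lower from compound 1 to compound 2 (beyond the scatter). Compound 4 `Cc1ccc(=O)n(CCC(=N)S)n1` differs from compound 2 by methyl in place of hydrogen on an aromatic carbon. Both measured steps concern a methyl on the saturated chain rather than on the ring, a number 11.5 percentage points lower from compound 1 to compound 2 (beyond the scatter) and a number 10 percentage points higher from compound 2 to compound 3 (within the scatter), so they bear on the new change only loosely. Each methyl added to the chain raised the number modestly, and a similar small rise, or none beyond the scatter, is expected here, a number 6.2 percentage points higher from compound 2 to compound 4 (within the scatter). Compound 4 is therefore estimated at 35%, with a range from 20% to 50%.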

Compound 4, a percentage reported as inhibition, in the whole organism at one dose (the size of the read-out at that dose, not a potency): 73.9%
Compound 4: the middle estimate sits 38.9 percentage points below what was measured; the whole stated range lies below it.
By their numbers in this assay, from the lowest: compounds 2, 3 and 1 (each within the scatter of the next, the first and the last beyond it); then compound 4.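

In this assay, methyl in place of hydrogen on an aromatic carbon, meta to a group of 5 heavy atoms, gives a number 45.1 percentage points higher from compound 2 to compound 4 (beyond the scatter), a large step. On a saturated chain carbon, the same exchange gave only a number 10 percentage points higher from compound 2 to compound 3 (within the scatter), so this ring position responds in a way the chain changes did not reveal. No evidence on hand explains the size of this step. The compounds shown leave open whether an ethyl group or a chlorine atom at this carbon would keep the gain. They also leave open whether a chain methyl adds to the ring methyl.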